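Sulfonamide variation on a shared dopamine receptor scaffold

The source may hold more compounds than are shown below. What is called first, only, known or untested is meant among the compounds shown, and "the series" means these compounds.

Among the compounds with values here, the compounds measured so far are compound 1 `CCCN(CC[C@H]1CC[C@H](NC(=O)/C=C/c2ccc(Cl)cc2)CC1)[C@H]1CCc2nc(N)sc2C1` with 2.5 nM, compound 2 `CCCN(CC[C@H]1CC[C@H](NC(=O)/C=C/c2ccccc2Cl)CC1)[C@H]1CCc2nc(N)sc2C1` with 1.2 nM, and compound 3 `CCCN(CC[C@H]1CC[C@H](NS(=O)(=O)c2cccc(Cl)c2)CC1)[C@H]1CCc2nc(N)sc2C1` with 1.1 nM, all in an assay on brain for displacement of a labelled ligand from D(3) dopamine receptor (Rattus norvegicus); on this read-out higher numbers stand for weaker inhibition and lower numbers for stronger inhibition.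

Compound 3 gives the lowest number of the three in this assay. Its nearest neighbour is compound 2 , and the step of a 1.1-fold lower number from compound 2 to compound 3 (0.04 log units; within the scatter) lies within the scatter, so no order between those two is claimed. Against compound 1 the step of a 2.3-fold lower number from compound 1 to compound 3 (0.36 log units; beyond the scatter) is modest but beyond the scatter, as is the step of a 2.1-fold lower number from compound 1 to compound 2 (0.32 log units; beyond the scatter).

Compound 4 `CCCN(CC[C@H]1CC[C@H](NS(=O)(=O)c2cccc(C)c2)CC1)[C@H]1CCc2nc(N)sc2C1` differs from compound 3 by methyl in place of chloro on an aromatic carbon. Within the data shown here, none of the measured steps touches this kind of change: the steps from compound 1 move the chloro around the ring or exchange the whole linker, and no pair swaps a chloro for a methyl. The measured steps were all modest or within the scatter, and the sulfonamide of compound 3 and the amide of compound 2 gave numbers within the scatter of each other. A methyl in place of a chloro is therefore expected to give at most a small change, with no direction beyond the scatter claimed, an expected step of a 1.8-fold higher number from compound 3 to compound 4 (0.26 log units; within the scatter). Compound 4 is estimated at 2 nM, between 0.7 nM and 6 nM.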

Compound 4, inhibition constant: 0.89 nM
For compound 4 the middle estimate is 2.2-fold (0.35 log units) above the measured one; the range from low to high includes it.
By their numbers in this assay, from the lowest: compounds 4, 3 and 2 (each within the scatter of the next); then compound 1.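

At the aromatic carbon meta to a large group, exchanging one heavy atom for another, chloro for methyl, gives a 1.2-fold lower number from compound 3 to compound 4 (0.09 log units; within the scatter) in this assay, so the chlorine is not needed to keep the number in this low range. Within the data shown here, with the methyl in place, the sulfonamide also stays level with the amide, with a 1.3-fold lower number from compound 2 to compound 4 (0.13 log units; within the scatter), while a 2.8-fold lower number from compound 1 to compound 4 (0.45 log units; beyond the scatter) is modest and the only one of the new steps that lies beyond the scatter. Nothing shown explains why the exchange of chloro for methyl leaves the number level at this position.

From the compounds shown here alone, both groups compared here are single heavy atoms without hydrogen-bond donors or acceptors, so it remains open whether the number would hold with a methoxy group, an amine or a carboxylic acid on the same aromatic carbon. Going by these compounds, it also remains open whether the level result for chloro and methyl would carry over to a longer chain such as propyl, or to the same exchange on the amides of compound 1 and compound 2.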